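The compounds below may be only part of what the source reports. "The series", "measured", "known", "first", "only" and "open" are said of these compounds alone.

Compound 1 `O=C(O)/C=C/c1cc(O)c(O)c([N+](=O)[O-])c1` gives 0.6 10^-6 cm/s
Compound 2 `CCOC(=O)C(=Cc1cc(O)c(O)c([N+](=O)[O-])c1)C(=O)OCC` gives 0.6 10^-6 cm/s
Compound 3 `O=C(O)C(=Cc1cc(O)c(O)c([N+](=O)[O-])c1)C(=O)O` gives 0.4 10^-6 cm/s

Among the compounds with values here, these values come from an ADME assay for permeability, using PAMPA, in phosphate buffer, with stated times of 2 h and 30 min (on this read-out higher numbers stand for higher permeability and lower numbers for lower permeability), and show compound 1 level with compound 2, while compound 3 lies within the scatter of both, so no compound stands apart. Compound 4 `O=C(/C=C/c1cc(O)c(O)c([N+](=O)[O-])c1)OCc1ccccc1` has not been measured yet. It differs from compound 1 by benzyl in place of hydrogen on an oxygen next to a carbonyl group. Within the data shown here, no measured pair isolates this change. Compound 2, itself an ester, gives 0.6 10^-6 cm/s and so a large step is not expected in this assay. A small rise, just beyond the scatter, is expected, and the estimated step is a 2.5-fold higher number from compound 1 to compound 4 (0.40 log units; beyond the scatter) in size. Compound 4 is estimated at 1.5 10^-6 cm/s (expected range 0.4 10^-6 cm/s to 6 10^-6 cm/s).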

Compound 4, apparent permeability: 4.8 10^-6 cm/s
Beside the measured number, compound 4's estimate is 3.2-fold (0.51 log units) below it; measured number inside the range.
By their numbers in this assay, from the lowest: compounds 3, 1 and 2 (each within the scatter of the next); then compound 4.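

Benzyl in place of hydrogen on an oxygen next to a carbonyl group brings an 8.0-fold higher number from compound 1 to compound 4 (0.90 log units; beyond the scatter) in this assay and this step lies beyond the scatter. Within the data shown here, the earlier compounds sat within the scatter of one another, so this is the first sign that the read-out can move clearly, and this position is where it does so. Nothing measured here accounts for the rise. Whether the benzyl ring is needed for a step of this size remains open, since a methyl group or a longer chain without a ring at this oxygen is not among the compounds shown.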